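Working notes: one fluoro exchanged for chloro in the series

The compounds below may be only part of what the source reports. "The series", "measured", "known", "first", "only" and "open" are said of these compounds alone.

Compound 1 (`O=C(Nc1nc(-c2ccccn2)cs1)c1ccccc1F`): "not determined" (no result reported)
Compound 2 (`O=C(Nc1nc(-c2ccccn2)cs1)c1c(F)cccc1F`): 3200 nM

Within the data shown here, in an ADME assay on Vero cells (Chlorocebus sabaeus) for cytotoxicity, read by MTT assay, with a stated time of 72 h (on this read-out lower numbers stand for an effect already at smaller amounts and higher numbers for an effect only at larger amounts of compound), compound 2 gives 3200 nM as the only number so far, and compound 1 offers no result to set beside it. Compound 2 therefore cannot yet be ranked against anything. Compound 3 (`O=C(Nc1nc(-c2ccccn2)cs1)c1c(F)cccc1Cl`) has not been measured. Its structure departs from compound 2 at one place (chloro in place of fluoro on an aromatic carbon): chloro in place of fluoro on an aromatic carbon, ortho to a large group and meta to a fluoro group. Among the measured compounds shown here, no measured step shows what such a change does in this assay. The expectation therefore rests on compound 2 with 3200 nM as its only anchor, and no shift beyond the usual scatter is expected in either direction. The expected step (a 1.1-fold lower number from compound 2 to compound 3 (0.06 log units; within the scatter)) is accordingly small. For compound 3 the estimated value is 2800 nM with an expected range from 1100 nM to 7500 nM as the working bracket.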

Compound 3, half-maximal effective concentration: 1300 nM
Compound 3: the middle estimate sits 2.2-fold (0.33 log units) above what was measured; the range from low to high includes it.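

In this assay, among these compounds, chloro in place of fluoro on an aromatic carbon, ortho to a large group and meta to a fluoro group, gives a 2.5-fold lower number from compound 2 to compound 3 (0.39 log units; beyond the scatter), the first measured step. This position is therefore not silent on this read-out: exchanging one heavy atom, with no ring, hydrogen-bond donor, hydrogen-bond acceptor or net charge entering or leaving, moves the number beyond the usual scatter, towards an effect at smaller amounts of compound. No measurement at hand bears on what lies behind this step, so it remains an observation without an assigned cause.

A single exchange at this position leaves open how other groups placed on the same aromatic carbon, such as methyl, methoxy, an amine or a carboxylic acid, would compare with fluoro and chloro in this assay. It also leaves open whether the same exchange of fluoro for chloro would give a step of similar size and direction with a different group in place of the remaining fluoro group.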